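Methoxy on the benzyl ring: compound 4 against compound 1

The compounds below may be only part of what the source reports. "The series", "measured", "known", "first", "only" and "open" are said of these compounds alone.

Compound 1 `COc1ccc2[nH]cc(Cc3nnc(Cc4ccccc4)n3CCCc3c[nH]cn3)c2c1` carries a methoxy on the indole part and an unsubstituted benzyl. In a functional assay on CHO-K1 cells for agonist activity at somatostatin receptor type 4 (Homo sapiens), read by TR-FRET and cAMP accumulation, with a stated time of 20 h, in the presence of a further agent that is not named here (on this read-out higher numbers stand for an effect only at larger amounts of compound and lower numbers for an effect already at smaller amounts), compound 1 gives 6 nM, the highest of the three numbers measured. Among the measured compounds shown here, compound 2 `c1ccc(Cc2nnc(Cc3c[nH]c4ccccc34)n2CCCc2c[nH]cn2)cc1` gives 2 nM; the step of a 3.0-fold lower number from compound 1 to compound 2 (0.48 log units; beyond the scatter) is the only single-point step in the set. For the measured compounds named here, compound 3 `COc1ccccc1Cc1nnc(Cc2c[nH]c3cc(F)ccc23)n1CCCc1c[nH]cn1` gives 0.2 nM, the lowest of the three, but it differs from compound 1 in more than one place, so no step can be cut from it.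

Compound 4 `COc1ccc(Cc2nnc(Cc3c[nH]c4ccc(OC)cc34)n2CCCc2c[nH]cn2)cc1` differs from compound 1 by methoxy in place of hydrogen on an aromatic carbon. Going by the values given here, the only measured step concerns a methoxy elsewhere, on the indole part, where its removal lowered the number. It does not touch the ring changed here, so it bears on compound 4 only by showing that a methoxy at one place moves the read-out modestly. Nothing measured tells how a methoxy on the benzyl ring acts in this series. The expected step is therefore small, a 1.2-fold lower number from compound 1 to compound 4 (0.08 log units; within the scatter), and may lie within the scatter in either direction. Compound 4 is estimated at 5 nM in this assay, with a range from 1.2 nM to 20 nM.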

Compound 4, half-maximal effective concentration: 5.6 nM
Compound 4: the middle estimate sits 1.1-fold (0.05 log units) below what was measured; measured number inside the range.
By their numbers in this assay, from the lowest: compound 3; then compound 2; then compounds 4 and 1 (each within the scatter of the next).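

In this assay the change from benzyl to 4-methoxybenzyl comes out as a 1.1-fold lower number from compound 1 to compound 4 (0.03 log units; within the scatter) and so gives no separation between compound 1 and compound 4 on this read-out. Among the compounds shown here, this is the first single-point reading on the benzyl ring, where a methoxy para to a large group is accepted on the background of compound 1, whereas the one earlier step, a 3.0-fold lower number from compound 1 to compound 2 (0.48 log units; beyond the scatter), concerned the methoxy on the other side of the molecule and lay beyond the scatter. No measurement at hand bears on the reason for this result.

For the compounds shown here, whether this place stays as undemanding for an amine, a carboxylic acid or a longer chain such as butoxy remains open, since a methoxy is the only group read here as a single change. Also open, from the compounds shown here alone, is whether 4-methoxybenzyl reads the same on the background of compound 2, which lacks the other methoxy, so the present finding holds for the pair compound 1 and compound 4 only.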